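The source may report more compounds than this note shows. Statements on the series, on what has been measured and on what is new or still open speak of the compounds shown alone.

Within the data shown here, in a functional assay on KB cells (Homo sapiens) for antiproliferative activity, read by sulforhodamine B assay, with a stated time of 3 days (on this read-out lower numbers stand for an effect already at smaller amounts and higher numbers for an effect only at larger amounts of compound), compound 3 `CCC1=C(O)c2c(oc(-c3ccc(O)c(O)c3)cc2=O)C(CC)(CC)C1=O` gives 10 uM, the lowest number so far and clear of its nearest neighbour. That neighbour, compound 1 `CCC1=C(O)c2c(oc(-c3ccc(C)cc3)cc2=O)C(CC)(CC)C1=O`, gives 39.2 uM. Compound 2 `CCC1=C(O)c2c(oc(-c3ccccc3F)cc2=O)C(CC)(CC)C1=O` is reported only as a limit, > 56.2 uM. Compound 4 `CCC1=C(O)c2c(oc(-c3cccc(C)c3C)cc2=O)C(CC)(CC)C1=O` has 2,3-dimethylphenyl in place of 3,4-dihydroxyphenyl on an aromatic carbon. The measured steps closest to this change run the other way: 3,4-dihydroxyphenyl replacing 4-methylphenyl gave a 3.9-fold lower number from compound 1 to compound 3 (0.59 log units; beyond the scatter), and replacing 2-fluorophenyl gave an at least 5.6-fold lower number from compound 2 to compound 3 (0.74 log units; beyond the scatter). Removing 3,4-dihydroxyphenyl is therefore expected to raise the number by a similar, modest size. The expected outcome is a 4.0-fold higher number from compound 3 to compound 4 (0.60 log units; beyond the scatter). For compound 4 the estimate is 40 uM, within a range of 18 uM to 85 uM.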

Compound 4, concentration for half-maximal effect: 3.1 uM
Estimate against measurement, compound 4: 13-fold (1.11 log units) above; measured number below the stated range.
By their numbers in this assay, from the lowest: compound 4; then compound 3; then compound 1. At a limit, above all of these: compound 2.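

In this assay, a low number does not depend on 3,4-dihydroxyphenyl: 2,3-dimethylphenyl, with 0 hydrogen-bond donors, gives a 3.2-fold lower number from compound 3 to compound 4 (0.51 log units; beyond the scatter). The methyl pattern on this phenyl ring matters too, as 2,3-dimethylphenyl replacing 4-methylphenyl gives a 13-fold lower number from compound 1 to compound 4 (1.10 log units; beyond the scatter), and replacing 2-fluorophenyl gives an at least 18-fold lower number from compound 2 to compound 4 (1.25 log units; beyond the scatter). That last step rests on a limit rather than a number: the limit of > 56.2 uM in this assay, at which 1 of the 4 values shown sits.

Still open, on these data alone, is how 2-methylphenyl or 3-methylphenyl alone would compare. Also open, as far as these compounds go, is whether a phenyl ring carrying an amine or a carboxylic acid would keep the number this low.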